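Isobutoxy in place of methoxy on an inactive pair

The source may hold more compounds than are shown below. What is called first, only, known or untested is meant among the compounds shown, and "the series" means these compounds.

Compound 1 `COc1ccc(-c2nc3cc(/C=C4\SC(=O)N(CC(=O)N5CCOCC5)C4=O)ccc3[nH]2)cc1OC` and compound 2 `COc1ccc(-c2nc3cc(/C=C4\SC(=O)N(Cc5cc(OC)c(OC)c(OC)c5)C4=O)ccc3[nH]2)cc1OC` share one core. In a functional assay on PC-3 cells (Homo sapiens) for inhibition, read by MTT assay, with a stated time of 48 h (on this read-out lower numbers stand for stronger inhibition and higher numbers for weaker inhibition), compound 1 gives only a limit, > 50000 nM. In this assay compound 2 likewise gives only a limit, > 50000 nM. The step that the two limits leave unreadable from compound 1 to compound 2 stays unreadable, both values sitting at the limit of > 50000 nM in this assay, at which 2 of the 2 values shown sit. Compound 3 `COc1cc(-c2nc3cc(/C=C4\SC(=O)N(Cc5cc(OC)c(OC)c(OC)c5)C4=O)ccc3[nH]2)ccc1OCC(C)C` differs from compound 2 by isopropyl in place of hydrogen on a saturated chain carbon bound to an oxygen on an aromatic ring. Within the data shown here, no measured step bears on this change, so the expected step that the limit leaves unreadable from compound 2 to compound 3 is an estimate only, most likely none beyond the scatter. Compound 3 is estimated at 60000 nM in this assay, range 20000 nM to 200000 nM, probably again a limit.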

Compound 3, half-maximal inhibitory concentration: 110 nM
The estimate for compound 3 lay 550-fold (2.74 log units) above the measured number; measured number outside the range, below it.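

Methoxy to isobutoxy, with the rest of compound 2 unchanged, is the only change shown that brings a measured number out of the limit in this assay, giving an at least 450-fold lower number from compound 2 to compound 3 (2.65 log units; beyond the scatter). The oxygen-bound chain on the aromatic ring is therefore a position where activity responds strongly, which the pair at the limit could not reveal. The true size of the step stays open on one side, since compound 2 gives only a limit: the limit of > 50000 nM in this assay, at which 2 of the 3 values shown sit.

Going by these compounds, whether ethoxy, n-butoxy or cyclopentyloxy would serve as well as isobutoxy remains open. So does whether isobutoxy would give a measurable number on compound 1, with its morpholinyl carbonyl group.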